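The source may hold more compounds than are shown below. What is called first, only, known or untested is meant among the compounds shown, and "the series" means these compounds.

Compound 1 `O=C(O)CN1C(=O)/C(=C/c2nc3ccccc3n2Cc2ccc(Br)cc2)SC1=S` gives 8720 nM in a functional assay on MDA-MB-231 cells (Homo sapiens) for cytotoxicity, read by MTT assay, with a stated time of 48 h; on this read-out higher numbers stand for weaker inhibition and lower numbers for stronger inhibition. Among the three measured compounds it holds the second highest number: compound 2 `N#Cc1ccc(Cn2c(/C=C3\SC(=S)N(CC(=O)O)C3=O)nc3ccccc32)cc1` gives 11200 nM, and compound 3 `O=C(O)CN1C(=O)/C(=C/c2nc3ccccc3n2Cc2ccc(Cl)cc2)SC1=S` gives 5580 nM. The three steps, a 1.3-fold higher number from compound 1 to compound 2 (0.11 log units; within the scatter), a 1.6-fold lower number from compound 1 to compound 3 (0.19 log units; within the scatter) and a 2.0-fold lower number from compound 2 to compound 3 (0.30 log units; within the scatter), are all within the scatter, so the three sit together on this read-out.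

Compound 4 `CCn1c(/C=C2\SC(=S)N(CC(=O)O)C2=O)nc2ccccc21` is the next candidate. Its difference from compound 1 is methyl in place of 4-bromophenyl on a saturated chain carbon bound to an aromatic nitrogen; cut one bond further out, the same difference reads 4-bromobenzyl to ethyl. Going by the values given here, none of the measured steps bears on this directly: each of them swaps one group on the aromatic ring of the benzyl, and all stay within the scatter, whereas here the whole ring leaves and a methyl enters. The measured steps therefore give no direction, and the change is larger than any of them, so a wide range is needed. Compound 4 is expected to give 15000 nM, with a range from 5000 nM to 45000 nM, which means an expected step of a 1.7-fold higher number from compound 1 to compound 4 (0.24 log units; within the scatter).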

Compound 4, half-maximal inhibitory concentration: 1880 nM
Estimate against measurement, compound 4: 8.0-fold (0.90 log units) above; the whole stated range lies above it.
By their numbers in this assay, from the lowest: compound 4; then compounds 3, 1 and 2 (each within the scatter of the next).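

In this assay, the place on a saturated chain carbon bound to an aromatic nitrogen proves sensitive to a change that swaps on the aromatic ring did not reveal: methyl in place of the whole substituted phenyl gives a 4.6-fold lower number from compound 1 to compound 4 (0.67 log units; beyond the scatter) and a 3.0-fold lower number from compound 3 to compound 4 (0.47 log units; beyond the scatter) and a 6.0-fold lower number from compound 2 to compound 4 (0.78 log units; beyond the scatter), each beyond the scatter. Within these four compounds, the substituted benzyl is therefore not required for activity on this read-out, and ethyl-bearing compound 4 has the lowest number. No measurement shown accounts for this shift.

Ethyl alone cannot separate the loss of the aromatic ring from the shortening of the chain. On these data alone, whether an unsubstituted benzyl or a longer chain such as butyl would fall with compound 4 or with compounds 1, 2 and 3 remains open.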